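The source may hold more compounds than are shown below. What is called first, only, known or untested is meant among the compounds shown, and "the series" means these compounds.

Measured in a functional assay on Jurkat cells (Homo sapiens) for antiproliferative activity, read by MTT assay, with a stated time of 72 h; a higher number here means a weaker inhibitor, a lower number a stronger inhibitor:
Compound 1 `COc1cc(-n2ncnc2-c2ccc(C)cc2)cc(OC)c1OC`: 300 nM
Compound 2 `CCOc1ccc(-c2ncnn2-c2cc(OC)c(OC)c(OC)c2)cc1Cl`: 3 nM
Compound 3 `COc1cc(-c2ncnn2-c2ccc([N+](=O)[O-])cc2)cc(OC)c1OC`: > 10000 nM (a limit, not a number)

Of the two true numbers in this assay, compound 1 has the higher at 300 nM. Compound 2 gives 3 nM, and the gap between these two numbers lies beyond the scatter. Compound 3 sits at the limit of the assay, > 10000 nM.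

The next step leads to compound 4 `COc1cc(-n2ncnc2-c2ccccc2)cc(OC)c1OC`, which puts hydrogen in place of methyl on an aromatic carbon, para to a large group: hydrogen in place of methyl on an aromatic carbon. This turns 4-methylphenyl into phenyl. Within the data shown here, no measured pair isolates this change, so the expectation is only tentative. It rests on compound 1 at 300 nM and compound 2 at 3 nM, both of which carry substituents on the corresponding ring. A weakening beyond the scatter is expected, with an estimated step of a 5.0-fold higher number from compound 1 to compound 4 (0.70 log units; beyond the scatter). For compound 4 the estimated value is 1500 nM, with an expected range of 250 nM to 10000 nM.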

Compound 4, half-maximal inhibitory concentration: > 10000 nM
Compound 4: only a limit was reported (the forecaster's own chance of this, stated with the estimate: 25%); at least 6.6-fold (0.82 log units) between middle value and limit.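

Going from methyl to hydrogen on an aromatic carbon, para to a large group, gives an at least 33-fold higher number from compound 1 to compound 4 (1.52 log units; beyond the scatter) in this assay, a large loss for the removal of a single carbon. Compound 4 stands at > 10000 nM, which is a limit and not a number. The methyl of the 4-methylphenyl ring of compound 1 therefore matters to activity in this series, but the step fixes only a lower bound on the size of the change, set by the top of the assay range: the limit of > 10000 nM in this assay, at which 2 of the 4 values shown sit.

From the compounds shown here alone, whether methyl is specifically needed remains open, as only hydrogen has been compared with it in a single-place change. Ethyl, methoxy, fluorine or an amine at this position would show whether other groups retain the activity of compound 1.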